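A few compounds are considered here, and "the series" means these few. Any claim that something is new, unique, unknown or untested is made for them only; others in the source may bear on it.

The series shares one core, carried in compound 1 `CC(=O)Oc1cccc(N2C(=O)/C(=C/N3N=C(c4ccccc4)CC3c3ccccc3O)SC2=S)c1` and in compound 2 `CC(=O)Oc1ccc(N2C(=O)/C(=C/N3N=C(c4ccccc4)CC3c3ccccc3O)SC2=S)cc1`. Within the data shown here, in a functional assay on HL-60 cells (Homo sapiens) for antiproliferative activity, read by MTT assay, with a stated time of 72 h (a lower number here means a stronger inhibitor, a higher number a weaker inhibitor), compound 1 gives 118 nM, while compound 2 gives 9400 nM, the higher of the two numbers so far; the single step of an 80-fold higher number from compound 1 to compound 2 (1.90 log units; beyond the scatter) moves a 4-acetoxyphenyl to a 3-acetoxyphenyl on the amide-type nitrogen in the ring and shows how strongly this position governs this assay. Compound 3 `CN1C(=O)/C(=C/N2N=C(c3ccccc3)CC2c2ccccc2O)SC1=S` is the next member, not yet measured. It differs from compound 2 by methyl in place of 4-acetoxyphenyl on an amide-type nitrogen in a ring. Among the measured compounds shown here, no measured step replaces the 4-acetoxyphenyl with a small alkyl group, so the direction is open: the only step known, from compound 1 to compound 2, bears on the same position and was large, which argues for a sizeable change in this assay rather than none, but it does not say whether the number should fall or rise. The estimate for compound 3 is therefore set near compound 2 with a broad span, 3000 nM within 300 nM to 30000 nM, which corresponds to an expected step of a 3.1-fold lower number from compound 2 to compound 3 (0.50 log units; beyond the scatter).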

Compound 3, half-maximal inhibitory concentration: 2880 nM
Beside the measured number, compound 3's estimate is 1.0-fold (0.02 log units) above it; the range from low to high includes it.
By their numbers in this assay, from the lowest: compound 1; then compound 3; then compound 2.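

In this assay the change to methyl gives a 3.3-fold lower number from compound 2 to compound 3 (0.51 log units; beyond the scatter) and so shows that an aryl group on this nitrogen is not needed for activity, since the 4-acetoxyphenyl group does worse here than the single carbon that replaces it. The comparison with the other isomer gives a 24-fold higher number from compound 1 to compound 3 (1.39 log units; beyond the scatter) and places methyl between the two acetoxyphenyl groups, so the bulk of the substituent does not order these numbers: the two groups of the same composition supply both the lowest and the highest value, and only the 3-acetoxyphenyl group stands well clear of methyl. No measurement at hand accounts for this order.

What the compounds shown leave open is whether the acetoxy group itself matters at the 3-position, which a plain phenyl, a 3-hydroxyphenyl or a 3-methoxyphenyl group on this nitrogen would test. Going by these compounds, it is also open how a longer chain such as butyl, or a chain ending in a carboxylic acid or an amine, would compare with methyl in this position.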